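The compounds below may be only part of what the source reports. "The series", "measured", "known", "first", "only" and "open" are said of these compounds alone.

Compound 1 `Cc1cc(C)c(-c2nc(CN3CCC(C(=O)NCCCN4C[C@H](C)C[C@H](C)C4)CC3)c(C)o2)c(C)c1`: > 0.5 h (a limit)
Compound 2 `Cc1cccc(C)c1-c1nc(CN2CCC(C(=O)NCCCN3C[C@H](C)C[C@H](C)C3)CC2)c(C)o1`: 0.0517 h

Among the measured compounds shown here, in an ADME assay on microsomes from liver (Rattus norvegicus) for metabolic stability, read by LC-MS, using NADPH, at 37 degrees C (on this read-out lower numbers stand for a shorter-lived compound and higher numbers for a longer-lived compound), compound 2 gives 0.0517 h, the only actual number so far. For compound 1 the entry > 0.5 h is a limit. Compound 3 `Cc1ccc(-c2nc(CN3CCC(C(=O)NCCCN4C[C@H](C)C[C@H](C)C4)CC3)c(C)o2)cc1C` differs from compound 2 by 3,4-dimethylphenyl in place of 2,6-dimethylphenyl on an aromatic carbon. For the measured compounds named here, the one measured step, an at least 9.6-fold lower number from compound 1 to compound 2 (0.98 log units; beyond the scatter), falls on the same group, but it puts hydrogen in place of methyl, whereas compound 3 keeps both methyl groups, so it sets no direction here. In this assay the expected change is small, an estimated 1.2-fold higher number from compound 2 to compound 3 (0.06 log units; within the scatter). Compound 3 is expected at 0.06 h, with an estimated range of 0.02 h to 0.2 h.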

Compound 3, half-life: > 0.5 h
Compound 3 was reported as a limit; the forecaster's own chance of this, stated with the estimate: 8%; middle value at least 8.3-fold (0.92 log units) from the limit.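

In this assay, the same atoms joined differently give an at least 9.6-fold higher number from compound 2 to compound 3 (0.98 log units; beyond the scatter), so at this position the placement of the methyl groups on the phenyl ring counts, not just their number. The 2,6-dimethylphenyl of compound 2 now stands apart from both other groups, and the value of compound 3 is a limit. The step from compound 1 to compound 3 cannot be read, as both entries are limits: the limit of > 0.5 h in this assay, at which 2 of the 3 values shown sit.

Still open, going by these compounds, is how far compound 3 lies past its limit. Also open, on these data alone, is how a methoxy group or a chlorine atom on this phenyl ring would read.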